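Swapping the aryl group on the ring nitrogen

The source may report more compounds than this note shows. Statements on the series, on what has been measured and on what is new or still open speak of the compounds shown alone.

Compound 3 `N#CC1=C(N)Oc2c(N)cc3nc4ccccc4nc3c2C12C(=O)N(Cc1cnnn1-c1ccc([N+](=O)[O-])cc1)c1ccccc12` gives in a functional assay on HCT-116 cells (Homo sapiens) for antiproliferative activity, read by MTT assay, with a stated time of 48 h (a higher number here means a weaker inhibitor, a lower number a stronger inhibitor), only a limit, > 50000 nM, and thus stands at the limit of > 50000 nM in this assay, at which 2 of the 3 values shown sit. Compound 2 `CCc1ccccc1-n1nncc1CN1C(=O)C2(C(C#N)=C(N)Oc3c(N)cc4nc5ccccc5nc4c32)c2ccccc21` gives 10300 nM in this assay. For the measured compounds named here, the single measured step joining these two, an at least 4.8-fold higher number from compound 2 to compound 3 (0.68 log units; beyond the scatter), came with 4-nitrophenyl in place of 2-ethylphenyl on an aromatic nitrogen. Compound 1 `Cc1ccc(-n2nncc2CN2C(=O)C3(C(C#N)=C(N)Oc4c3c3nc5ccccc5nc3c3ccccc43)c3ccccc32)cc1Cl`, which bears the 5-chloro-2-methylphenyl group on a different core, gives only a limit, > 50000 nM, in this assay. Compound 4 `Cc1ccc(Cl)cc1-n1nncc1CN1C(=O)C2(C(C#N)=C(N)Oc3c(N)cc4nc5ccccc5nc4c32)c2ccccc21` is yet to be measured in this assay; it differs from compound 3 in that (5-chloro-2-methylphenyl in place of 4-nitrophenyl on an aromatic nitrogen). The step bearing on this change is an at least 4.8-fold higher number from compound 2 to compound 3 (0.68 log units; beyond the scatter), which the new change would partly reverse, so a modest move toward a lower number is expected. Compound 4 is therefore estimated at 30000 nM, within 8000 nM to 100000 nM. The estimated step is an at least 1.6-fold lower number from compound 3 to compound 4 (0.22 log units; that floor lies within the scatter).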

Compound 4, half-maximal inhibitory concentration: 37200 nM
For compound 4 the middle estimate is 1.2-fold (0.09 log units) below the measured one, within the range that was stated.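

On the shared core, the 5-chloro-2-methylphenyl group gives a second comparison with 2-ethylphenyl, a 3.6-fold higher number from compound 2 to compound 4 (0.56 log units; beyond the scatter), so both replacements of 2-ethylphenyl shown here leave a higher number. Against 4-nitrophenyl, the change gives an at least 1.3-fold lower number from compound 3 to compound 4 (0.12 log units; that floor lies within the scatter), and this step settles no order, as one end of it is a limit: the limit of > 50000 nM in this assay, at which 2 of the 4 values shown sit.

Left open is how an unsubstituted phenyl or a benzyl group on this aromatic nitrogen would read in this assay. Also open, going by these compounds, is whether the chlorine or the methyl of 5-chloro-2-methylphenyl goes with the step from 2-ethylphenyl.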